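Lengthening the Chain: From Compound 1 to Compound 3

This account rests on a few compounds, and the source may have more. Where it says the series, first, only, none or still open, it means among the compounds named here.

Measured so far:
compound 1, `C/N=C(\S)NCCCn1nc(-c2ccccc2)ccc1=O`: > 100 mg/kg
compound 2, `CN(C)/C(=N/CCCCCCn1nc(-c2ccccc2)ccc1=O)NC#N`: 93.1 mg/kg

Both were tested in a functional assay on the whole organism (stomach) with Rattus norvegicus as the target; on this read-out lower numbers stand for an effect already at smaller amounts and higher numbers for an effect only at larger amounts of compound. Compound 1 reached only a limit of the assay, > 100 mg/kg, so its position is known merely as a bound, not as a number (the limit of > 100 mg/kg in this assay, at which 1 of the 2 values shown sits). Compound 2 gave a number, 93.1 mg/kg. Compound 3, `CC/N=C(\S)NCCCCn1nc(-c2ccccc2)ccc1=O`, has not yet been measured in this assay; it differs from compound 1 by a group of 7 heavy atoms (4 carbon, 2 nitrogen, 1 sulfur; no ring) in place of a group of 5 heavy atoms (2 carbon, 2 nitrogen, 1 sulfur; no ring), on a saturated chain carbon, three bonds along the chain from an aromatic nitrogen. Within the data shown here, no step between two measured compounds is available, so the effect of such a change cannot be read off from a pair already known. The expected change here, a number no higher from compound 1 to compound 3 (the limit leaves the size open), is no step beyond the usual scatter, since compound 1 itself sits at the bound (the limit of > 100 mg/kg in this assay, at which 1 of the 2 values shown sits). Compound 3 is therefore estimated at 100 mg/kg, with a range from 50 mg/kg to 200 mg/kg, and a real chance that only a limit is reported again.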

Compound 3, dose for half-maximal effect: 37.2 mg/kg
Estimate against measurement, compound 3: 2.7-fold (0.43 log units) above; measured number outside the range, below it.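

The place on a saturated chain carbon, three bonds along the chain from an aromatic nitrogen, proves sensitive to what it carries: in this assay the group of 7 heavy atoms gives an at least 2.6-fold lower number from compound 1 to compound 3 (0.42 log units; beyond the scatter) when it replaces the group of 5 heavy atoms. Among these compounds, no earlier pair could show this, and compound 3 gives 37.2 mg/kg as a real number rather than a limit. The step can be stated only as a minimum because compound 1 stands at a limit: the limit of > 100 mg/kg in this assay, at which 1 of the 3 values shown sits.

The entering group differs from the leaving one by carbon atoms alone, and the compounds shown do not tell whether it matters where in the group those carbons sit. As far as these compounds go, how a still longer chain or an amine at this place would read also remains open.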